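This account rests on a few compounds, and the source may have more. Where it says the series, first, only, none or still open, it means among the compounds named here.

Series in a functional assay on C6 cells (Rattus norvegicus) for inhibition, read by sulforhodamine B assay, with a stated time of 72 h; a lower number here means that less compound is needed, a higher number that more compound is needed for the effect:
- compound 1 `O=C(/C=C/c1ccc([N+](=O)[O-])o1)c1ccc(I)cc1`: 2100 nM
- compound 2 `CCCCc1ccc(C(=O)/C=C/c2ccc([N+](=O)[O-])o2)cc1`: 1700 nM
- compound 3 `O=C(/C=C/c1ccc([N+](=O)[O-])o1)c1ccc(-n2ccnc2)cc1`: 3500 nM

Compound 1 stands second highest of the three numbers, but its steps to both others lie within the scatter. Compound 4 `O=C(/C=C/c1ccc([N+](=O)[O-])o1)c1ccc(-c2ccccc2)cc1` has phenyl in place of iodo on an aromatic carbon, para to a large group: phenyl in place of iodo on an aromatic carbon. Three measured steps change the same place. Two stay within the scatter, a 1.2-fold lower number from compound 1 to compound 2 (0.09 log units; within the scatter) and a 1.7-fold higher number from compound 1 to compound 3 (0.22 log units; within the scatter), and the largest, a 2.1-fold higher number from compound 2 to compound 3 (0.31 log units; beyond the scatter), is modest. No step beyond the scatter is therefore expected in this assay, and no direction is favoured. The expected step is a 1.0-fold higher number from compound 1 to compound 4 (0.02 log units; within the scatter). For compound 4 the estimated value is 2200 nM, with an expected range of 1100 nM to 4400 nM.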

Compound 4, half-maximal effective concentration: 17700 nM
Compound 4: the middle estimate sits 8.0-fold (0.91 log units) below what was measured, outside the stated range (above it).
By their numbers in this assay, from the lowest: compounds 2, 1 and 3 (each within the scatter of the next, the first and the last beyond it); then compound 4.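

In this assay this position, on an aromatic carbon para to a large group, proves sensitive to the group it carries, as phenyl gives (an 8.4-fold higher number from compound 1 to compound 4 (0.93 log units; beyond the scatter)) and (a 5.1-fold higher number from compound 3 to compound 4 (0.70 log units; beyond the scatter)) and (a 10-fold higher number from compound 2 to compound 4 (1.02 log units; beyond the scatter)). A ring alone does not account for this, since compound 3 also carries one, as 1H-imidazol-1-yl, yet stays close to compound 1. No measurement shown gives a reason for the steps to compound 4.

Open, on these data alone, is whether the higher number belongs to phenyl alone or would also come with a cyclohexyl or pyridyl group here.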